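From methoxycarbonyl to phenyl at the assay limit

The source may report more compounds than this note shows. Statements on the series, on what has been measured and on what is new or still open speak of the compounds shown alone.

In a functional assay on Huh7.5.1 cells (Homo sapiens) for cytotoxicity, read by MTT assay, with a stated time of 72 h (a lower number here means that less compound is tolerated, a higher number that more compound is tolerated), compound 1 `C=c1[nH]c(=O)/c(=C/c2c[nH]c3ccccc23)[nH]c1=O` gives > 20000 nM which is a limit and not a number. Compound 2 `C=c1[nH]c(=O)/c(=C/c2ccccc2)[nH]c1=O` gives > 20000 nM which is likewise a limit. Compound 3 `C=c1[nH]c(=O)/c(=C/c2ccc(C(=O)OC)cc2)[nH]c1=O` stands at > 20000 nM which is again only a limit, so it has no read number. Among the compounds with values here, the picture so far is the limit of > 20000 nM in this assay, at which 3 of the 3 values shown sit, and no compound has given a read value.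

Compound 4 `C=c1[nH]c(=O)/c(=C/c2ccc(-c3ccccc3)cc2)[nH]c1=O` carries phenyl in place of the methoxycarbonyl of compound 3 on an aromatic carbon, para to a large group, as counted in phenyl in place of methoxycarbonyl on an aromatic carbon with the shared core unchanged. Within the data shown here, the one measured step bearing on this place is a step that the two limits leave unreadable from compound 2 to compound 3 with methoxycarbonyl in place of hydrogen on an aromatic carbon. Its size cannot be read, so it offers no direction. The expectation therefore rests on compound 3 at > 20000 nM as a limit. In this assay the expected size of a number no higher from compound 3 to compound 4 (the limit leaves the size open) is none beyond the scatter, in neither direction. For compound 4 the estimated half-maximal cytotoxic concentration is 20000 nM with an expected range from 8000 nM to 30000 nM and another limit is the likeliest report.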

Compound 4, half-maximal cytotoxic concentration: > 20000 nM
Compound 4 ended at the assay's limit; the forecaster's own chance of this, stated with the estimate: 70%; the middle value sits exactly at the limit.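

In this assay, within the data shown here, compound 4 gives > 20000 nM, which is a limit and not a number, so no step from compound 2 or compound 3 to compound 4 can be read. Left open is whether phenyl or methoxycarbonyl in place of hydrogen shifts the half-maximal cytotoxic concentration at all: the limit of > 20000 nM in this assay, at which 4 of the 4 values shown sit.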